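A hydroxy added to the pendant phenyl ring

This account rests on a few compounds, and the source may have more. Where it says the series, first, only, none or still open, it means among the compounds named here.

Measured so far:
compound 1 `COc1cc2c(c(OC)c1O)C(=O)[C@H](O)[C@@H](c1ccc(O)cc1)O2` — 13.4%
compound 2 `COc1cc2c(c(OC)c1OC)C(=O)[C@H](O)[C@@H](c1ccc(O)cc1)O2` — 5.1%

Compound 1 and compound 2 were both tested in a functional assay on PC-12 cells (Rattus norvegicus) for cytotoxicity, read by MTT assay, with stated times of 2 h and 4 h, tested at 16 ug/mL; a lower number here means a weaker effect, a higher number a stronger effect of the compound at the concentration tested. Of the two numbers, compound 2 stands lowest, with compound 1 nearest; the step of a number 8.3 percentage points lower from compound 1 to compound 2 (within the scatter) is within the scatter, so the two compounds cannot be told apart on these figures.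

Compound 3 `COc1cc2c(c(OC)c1OC)C(=O)[C@H](O)[C@@H](c1ccc(O)c(O)c1)O2` is not yet measured. It differs from compound 2 by hydroxy in place of hydrogen on an aromatic carbon. Among the measured compounds shown here, no measured step here concerns a hydroxy entering an aromatic carbon; the only step known, the methyl for hydrogen on an oxygen from compound 1 to compound 2, was within the scatter. For the measured compounds named here, with no step of this kind to draw on, compound 3 is expected to sit close to compound 2, with a step of a number 2.9 percentage points higher from compound 2 to compound 3 (within the scatter) that stays within the scatter. Compound 3 is therefore estimated at 8% in this assay, between 0% and 20%.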

Compound 3, a percentage reported as activity, at one concentration (the size of the read-out at that concentration, not a potency): 56.1%
Beside the measured number, compound 3's estimate is 48.1 percentage points below it, outside the stated range (above it).
By their numbers in this assay, from the lowest: compounds 2 and 1 (each within the scatter of the next); then compound 3.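

In this assay, hydroxy in place of hydrogen on the aromatic carbon ortho to a hydroxy group of the pendant ring gives a number 51 percentage points higher from compound 2 to compound 3 (beyond the scatter). Among the compounds shown here, the only earlier change lay on an oxygen of the shared core, a number 8.3 percentage points lower from compound 1 to compound 2 (within the scatter), and it could not separate its two compounds, so this carbon of the pendant ring, going from 4-hydroxyphenyl to 3,4-dihydroxyphenyl, is the first place where a single change moves the read-out beyond the scatter. Nothing shown here offers a measured reason for this step.

The compounds shown leave open whether the rise needs a hydroxy at this carbon, or whether a methoxy, an amine or a fluorine there would give a step of similar size. They also leave open whether the same hydroxy would give a comparable step on the core of compound 1, which keeps a free hydroxy where compound 2 has a methoxy.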